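The compounds below may be only part of what the source reports. "The series", "measured", "known", "first", "only" and "open" are said of these compounds alone.

Compound 1 `CCSc1nc2c(n1Cc1ccc(OC)cc1)C(=O)N(CC)C1=N[C@@H]3CCC[C@@H]3N12` and compound 2 `CCSc1nc2c(n1Cc1ccc(O)cc1)C(=O)N(CC)C1=N[C@@H]3CCC[C@@H]3N12` are built on one shared core. In a physicochemical assay for lipophilicity, measured as octanol-water partition (on this read-out lower numbers stand for lower lipophilicity and higher numbers for higher lipophilicity), compound 1 gives 4.67, and compound 2 gives 4.41. The change between them is hydrogen in place of methyl on an oxygen on an aromatic ring and it made a step of a number 0.26 log units lower from compound 1 to compound 2 (within the scatter). Compound 3 `CCN1C(=O)c2c(nc(C(N)=O)n2Cc2ccc(OC)c(Br)c2)N2C1=N[C@@H]1CCC[C@@H]12` rests on a different core, and the difference between the two cores is not broken down here. In this assay, among the compounds with values here, compound 3 gives 3.3, the lowest of the three numbers so far; its gaps to compound 2 and to compound 1 both lie beyond the scatter. Compound 4 `CCN1C(=O)c2c(nc(C(N)=O)n2Cc2ccc(O)c(Br)c2)N2C1=N[C@@H]1CCC[C@@H]12` has not yet been measured. Within the data shown here, it differs from compound 3 by hydrogen in place of methyl on an oxygen on an aromatic ring, which is the same change as the one from compound 1 to compound 2, made at a place described in the same words. Among the four compounds this change occurs twice in all. Because the earlier step of a number 0.26 log units lower from compound 1 to compound 2 (within the scatter) stayed within the scatter, the step expected from that change onto compound 4 is a number 0.25 log units lower from compound 3 to compound 4 (within the scatter). This rests on a single measured pair on a different core, so the expectation carries a margin. The estimated value for compound 4 in this assay is 3.05, within an expected range from 2.7 to 3.4.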

Compound 4, partition coefficient: 3.03
The estimate for compound 4 lay 0.02 log units above the measured number, and the stated range covers the measured number.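

In this assay, swapping methoxy for hydroxy made a step of a number 0.27 log units lower from compound 3 to compound 4 (within the scatter), and the same swap on the core of compound 1 made a step of a number 0.26 log units lower from compound 1 to compound 2 (within the scatter), so the change had a step of much the same size on both cores. Within the data shown here, this supports carrying the step from one core to the other within these four compounds, but it rests on only two pairs, and with each step inside the scatter, neither pair alone shows that the swap truly moves the number. Nothing given here accounts for the size of the step or for its match across the two cores.

The compounds shown carry only methoxy or hydroxy at this place, so it stays open whether an amine, a carboxylic acid or a longer chain such as propoxy would also behave alike on both cores. From the compounds shown here alone, it also stays open whether the swap would give a step of this size on a third core, or whether the match seen in this assay would hold in any other read-out.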